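Sulfonamide series against orexin receptor type 2: compound 4

The compounds below may be only part of what the source reports. "The series", "measured", "known", "first", "only" and "open" are said of these compounds alone.

Measured so far in a functional assay on CHO cells for inhibition of Orexin receptor type 2 (Homo sapiens), read by FLIPR and calcium flux; a lower number here means a stronger inhibitor, a higher number a weaker inhibitor:
- compound 1, `CCN(CC)C(=O)CN(c1ccc(C)cc1)S(=O)(=O)c1cccc(C)c1`, gives 60 nM
- compound 2, `CCN(CC)C(=O)CN(c1cc2c(C)nsc2cc1Cl)S(=O)(=O)c1ccc(OC)c(OC)c1`, gives 4.5 nM
- compound 3, `CCN(C(=O)CN(c1cc2c(C)nsc2cc1Cl)S(=O)(=O)c1ccc(OC)c(OC)c1)c1ccccn1`, gives 5 nM

Compound 2 holds the lowest number of the three. Compound 3 sits nearest, with a 1.1-fold higher number from compound 2 to compound 3 (0.05 log units; within the scatter), so these two cannot be told apart. Among the compounds with values here, compound 1 is the furthest away and its number lies beyond the scatter from that of compound 2; no single step joins the two, as they differ in more than one place.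

Compound 4, `CCN(CC)C(=O)CN(c1cc(Cl)ccc1N(C)C)S(=O)(=O)c1ccc(OC)c(OC)c1`, is not yet measured. It differs from compound 2 by a group of 10 heavy atoms (8 carbon, 1 nitrogen, 1 chlorine; one six-membered aromatic ring of carbon only) in place of a group of 11 heavy atoms (8 carbon, 1 nitrogen, 1 sulfur, 1 chlorine; one five-membered aromatic ring with 2 hetero atoms, one six-membered aromatic ring of carbon only), on a sulfonamide nitrogen. Within the data shown here, no measured step touches this part of the molecule: the only step on hand, from compound 2 to compound 3, concerns the amide-type nitrogen and stays within the scatter, so it gives no guide to a change on the sulfonamide nitrogen. From the compounds shown here alone, the gap between compound 1 and compound 2 shows that groups on this nitrogen and on the sulfonyl can move the number well beyond the scatter, but which of the two sides carries that gap is unknown.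

Among the measured compounds shown here, with no direct precedent, a moderate rise in the number is expected for compound 4, a 3.3-fold higher number from compound 2 to compound 4 (0.52 log units; beyond the scatter), which is an estimate rather than a measurement. The estimated value of compound 4 in this assay is 15 nM, in the range 4 nM to 60 nM.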

Compound 4, half-maximal inhibitory concentration: 60 nM
Estimate against measurement, compound 4: 4.0-fold (0.60 log units) below; low and high end bracket the measured number.
By their numbers in this assay, from the lowest: compounds 2 and 3 (each within the scatter of the next); then compounds 1 and 4 (each within the scatter of the next).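

In this assay, the group on the sulfonamide nitrogen now has a measured step of its own: the exchange for 5-chloro-2-(dimethylamino)phenyl gives a 13-fold higher number from compound 2 to compound 4 (1.12 log units; beyond the scatter). Within the data shown here, this shows that a change at this position alone, with the rest of the molecule held constant, can move the number beyond the scatter, whereas the only earlier single-place step, at the amide-type nitrogen, gave a 1.1-fold higher number from compound 2 to compound 3 (0.05 log units; within the scatter). No measurement on hand accounts for the size of the new step.

The new group differs from the old one in more than one feature, so the compounds shown do not separate the loss of the five-membered aromatic ring from the presence of the dimethylamino group, and a 5-chloro-2-methoxyphenyl or 5-chloro-2-(morpholin-4-yl)phenyl group on the same nitrogen would help to divide the step between these features. Also open is whether the step carries over to the pyridin-2-yl amide of compound 3, since the sulfonamide-nitrogen change is shown only with the diethyl amide.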